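From amide to aromatic ring on the shared core

The compounds below may be only part of what the source reports. "The series", "measured", "known", "first", "only" and "open" are said of these compounds alone.

Compound 1 `CCN(CC)S(=O)(=O)c1ccc(S(=O)(=O)N2CCC[C@@H](C(=O)N(C)C(C)C)C2)cc1`: 6200 nM
Compound 2 `CCN(CC)C(=O)[C@@H]1CCCN(S(=O)(=O)c2ccc(S(=O)(=O)N(CC)CC)cc2)C1`: 6400 nM
Compound 3 `CCN(CC)S(=O)(=O)c1ccc(S(=O)(=O)N2CCC[C@@H](C(=O)NC3COC3)C2)cc1`: 2300 nM

In a functional assay on MIA PaCa-2 cells (Homo sapiens) for inhibition, read by MTT assay, with a stated time of 7 days (a higher number here means a weaker inhibitor, a lower number a stronger inhibitor), compound 3 stands lowest of the three numbers, with a 2.7-fold lower number from compound 1 to compound 3 (0.43 log units; beyond the scatter) and a 2.8-fold lower number from compound 2 to compound 3 (0.44 log units; beyond the scatter) both beyond the scatter, while a 1.0-fold higher number from compound 1 to compound 2 (0.01 log units; within the scatter) lies within it. Compound 4 `CCN(CC)S(=O)(=O)c1ccc(S(=O)(=O)N2CCC[C@@H](c3nc(C)no3)C2)cc1` differs from compound 3 as follows: 3-methyl-1,2,4-oxadiazol-5-yl in place of (oxetan-3-yl)carbamoyl on a saturated ring carbon. Going by the values given here, no measured step touches this change; the two steps that bear on it, from compound 1 and compound 2 to compound 3, only show that altering the amide part shifts the number modestly. Compound 4 is therefore expected to move by a 1.5-fold higher number from compound 3 to compound 4 (0.18 log units; within the scatter), a step that may fall within the scatter. Compound 4 is estimated at 3500 nM, with a range from 1200 nM to 10000 nM.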

Compound 4, half-maximal inhibitory concentration: 4100 nM
Beside the measured number, compound 4's estimate is 1.2-fold (0.07 log units) below it; measured number inside the range.
By their numbers in this assay, from the lowest: compounds 3, 4, 1 and 2 (each within the scatter of the next, the first and the last beyond it).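

In this assay, putting 3-methyl-1,2,4-oxadiazol-5-yl on this saturated ring carbon in place of (oxetan-3-yl)carbamoyl gives a 1.8-fold higher number from compound 3 to compound 4 (0.25 log units; within the scatter). The comparisons with the other two amides, a 1.6-fold lower number from compound 2 to compound 4 (0.19 log units; within the scatter) and a 1.5-fold lower number from compound 1 to compound 4 (0.18 log units; within the scatter), also stay within the scatter, so among these compounds a carbamoyl group is not required at this position for a number in this range. Nothing at hand explains why the position accepts this change. The compounds shown leave open how a carboxylic acid or an aminomethyl group on this ring carbon would read, and whether an ethyl or longer chain in place of the methyl on the 3-methyl-1,2,4-oxadiazol-5-yl would shift the number.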